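A few compounds are considered here, and "the series" means these few. Any claim that something is new, unique, unknown or untested is made for them only; others in the source may bear on it.

Measured so far:
compound 1 `CC(C)(N)C(=O)N[C@H](COCc1ccccc1)c1nnnn1CCOC(=O)N1CC[C@@H](O)C1` — 1 nM
compound 2 `CC(=O)N[C@@H]1CCN(C(=O)OCCn2nnnc2[C@@H](COCc2ccccc2)NC(=O)C(C)(C)N)C1` — 3.3 nM

For the measured compounds named here, compound 2 stands higher of the two numbers in a functional assay on H4 cells with growth hormone secretagogue receptor type 1 (Homo sapiens) as the target, read by FLIPR; a higher number here means that more compound is needed for the effect, a lower number that less compound is needed: the only measured neighbour is compound 1, and the step of a 3.3-fold higher number from compound 1 to compound 2 (0.52 log units; beyond the scatter) is a modest one. Compound 3 `CC(C)(N)C(=O)N[C@H](COCc1ccccc1)c1nnnn1CCOC(=O)NC[C@H]1CCCO1` is not yet measured. It differs from compound 2 by ((oxolan-2-yl)methyl)amino in place of 3-acetamidopyrrolidin-1-yl on a carbonyl carbon. Going by the values given here, no measured step covers this exchange: the one known step, from compound 1 to compound 2, alters only a substituent on the ring that now leaves, and its modest size shows that changes in this part of the molecule are tolerated to some degree. With the whole ring replaced by an open-chain amine, compound 3 is estimated at 5 nM in this assay, within 1.5 nM to 20 nM, a step of a 1.5-fold higher number from compound 2 to compound 3 (0.18 log units; within the scatter) expected to be no larger than the scatter.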

Compound 3, half-maximal effective concentration: 9.5 nM
Compound 3: middle estimate off by 1.9-fold (0.28 log units), on the low side; low and high end bracket the measured number.
By their numbers in this assay, from the lowest: compound 1; then compound 2; then compound 3.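

In this assay the result shows that the carbonyl carbon need not carry a pyrrolidine bound through its ring nitrogen: ((oxolan-2-yl)methyl)amino in place of 3-acetamidopyrrolidin-1-yl gives a 2.9-fold higher number from compound 2 to compound 3 (0.46 log units; beyond the scatter) and still leaves a nanomolar number. Set against 3-hydroxypyrrolidin-1-yl, the same group gives a 9.5-fold higher number from compound 1 to compound 3 (0.98 log units; beyond the scatter) and this is the largest step among the three compounds, so the hydroxy-bearing ring stays the best of the groups shown at this position. Nothing available explains either step.

The compounds shown leave open whether the rise follows from losing the pyrrolidine or from the oxolane itself. A plain dimethylamino group or a 2-hydroxyethylamino chain on the same carbonyl carbon would help to separate these two readings.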